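Replacing the anilino arm of the shared core with azetidine

This account rests on a few compounds, and the source may have more. Where it says the series, first, only, none or still open, it means among the compounds named here.

Compound 1 `O=C1C=C(Nc2ccc(I)cc2)C(=O)c2c1nc1n2[C@H]2OC[C@@H](O)[C@H]2OC1` in a functional assay on MGC-803 cells (Homo sapiens) for inhibition, read by sulforhodamine B assay (on this read-out lower numbers stand for stronger inhibition and higher numbers for weaker inhibition), gives 1400 nM, the second highest of the three numbers recorded. Its neighbours are compound 3 `CCc1ccc(NC2=CC(=O)c3c(nc4n3[C@H]3OC[C@@H](O)[C@H]3OC4)C2=O)cc1`, which gives 1110 nM, and compound 2 `COc1ccc(NC2=CC(=O)c3c(nc4n3[C@H]3OC[C@@H](O)[C@H]3OC4)C2=O)cc1`, which gives 2150 nM; both of these gaps to compound 1 lie within the scatter. Going by the values given here, the only measured step, a 1.9-fold lower number from compound 2 to compound 3 (0.29 log units; within the scatter), exchanges one substituent on the aromatic ring for another and stays within the scatter, so the three anilines behave alike in this assay.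

Compound 4 `O=C1C=C(N2CCC2)C(=O)c2c1nc1n2[C@H]2OC[C@@H](O)[C@H]2OC1` is not yet measured. It differs from compound 1 by azetidin-1-yl in place of (4-iodophenyl)amino on a double-bonded ring carbon. Among the compounds with values here, no measured step touches this part of the molecule: every recorded compound keeps the (4-iodophenyl)amino or a related arylamino group, and the step from compound 2 to compound 3 only varies a group on that ring. The expectation therefore rests on the size of the change alone, with a wide range. Compound 4 is expected to give a weaker result, roughly a 2.9-fold higher number from compound 1 to compound 4 (0.46 log units; beyond the scatter), estimated at 4000 nM with a range from 1000 nM to 16000 nM.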

Compound 4, half-maximal inhibitory concentration: > 16000 nM
Compound 4 was reported as a limit (the forecaster's own chance of this, stated with the estimate: 15%); at least 4.0-fold (0.60 log units) between middle value and limit.
By their numbers in this assay, from the lowest: compounds 3, 1 and 2 (each within the scatter of the next). At a limit, above all of these: compound 4.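

Azetidin-1-yl in place of (4-iodophenyl)amino on the double-bonded ring carbon gives an at least 11-fold higher number from compound 1 to compound 4 (1.05 log units; beyond the scatter). Compounds 1, 2 and 3 all keep an arylamino arm and stay within the scatter of one another, so they gave no sign that this position is sensitive; the arm itself now proves to matter in this assay. The full size of the step stays unknown, as compound 4 stands at a limit and not at a number: the limit of > 16000 nM in this assay, at which 1 of the 4 values shown sits.

The change removes the aromatic ring and the hydrogen-bond donor of the arm together, and the compounds shown cannot tell which of the two counts. Cyclohexylamino, which keeps the amine hydrogen without the aromatic ring, and N-methylanilino, which keeps the aromatic ring without that hydrogen, would separate the two.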